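From 3,5-Dichlorophenyl to 2,4-Dichlorophenyl

This account rests on a few compounds, and the source may have more. Where it says the series, first, only, none or still open, it means among the compounds named here.

Three measured compounds share one core and differ only in the group attached to a carbonyl carbon. In a functional assay on Vero cells (Chlorocebus sabaeus) for inhibition (a lower number here means a stronger inhibitor, a higher number a weaker inhibitor), compound 1 `COc1cc(/C=C/C(=O)c2cccc(NC(=O)c3ccco3)c2)ccc1O` gives 3.11 ug/mL. Compound 3 `CCCC(=O)Nc1cccc(C(=O)/C=C/c2ccc(O)c(OC)c2)c1` gives 2.04 ug/mL, a step of a 1.5-fold lower number from compound 1 to compound 3 (0.18 log units; within the scatter). As far as these compounds go, compound 2 `COc1cc(/C=C/C(=O)c2cccc(NC(=O)c3cc(Cl)cc(Cl)c3)c2)ccc1O` reaches only the limit of this assay, > 50 ug/mL, so its true number is unknown. It stands as the weakest of the three. The two steps involving it were large, an at least 16-fold higher number from compound 1 to compound 2 (1.20 log units; beyond the scatter) and an at least 24-fold lower number from compound 2 to compound 3 (1.38 log units; beyond the scatter), and compound 2 sits at the limit of > 50 ug/mL in this assay, at which 1 of the 3 values shown sits. Compound 4 `COc1cc(/C=C/C(=O)c2cccc(NC(=O)c3ccc(Cl)cc3Cl)c2)ccc1O` differs from compound 2 by 2,4-dichlorophenyl in place of 3,5-dichlorophenyl on a carbonyl carbon. Going by the values given here, no measured step moves chlorines within a ring. Compound 4 is expected to stay near that limit, at an estimated 40 ug/mL (from 10 ug/mL to 100 ug/mL), meaning an expected step of an at least 1.2-fold lower number from compound 2 to compound 4 (0.09 log units; that floor lies within the scatter).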

Compound 4, half-maximal inhibitory concentration: 27.2 ug/mL
Beside the measured number, compound 4's estimate is 1.5-fold (0.17 log units) above it; low and high end bracket the measured number.
By their numbers in this assay, from the lowest: compounds 3 and 1 (each within the scatter of the next); then compound 4. At a limit, above all of these: compound 2.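

Compound 2 holds only a limit, not a number: the limit of > 50 ug/mL in this assay, at which 1 of the 4 values shown sits. Moving the chlorines gives an at least 1.8-fold lower number from compound 2 to compound 4 (0.26 log units; that floor lies within the scatter), so whether their placement matters cannot yet be settled. A dichlorophenyl group now has a real number, and it remains a weaker choice on this carbonyl carbon than propyl or furan-2-yl: a 13-fold higher number from compound 3 to compound 4 (1.12 log units; beyond the scatter) and an 8.7-fold higher number from compound 1 to compound 4 (0.94 log units; beyond the scatter).

Still open, as far as these compounds go, is whether the chlorines or the six-membered ring itself account for this gap. A plain phenyl group, with no chlorine, at the same place would separate the two.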